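The compounds below may be only part of what the source reports. "The series", "measured", "known", "first", "only" and "open" are said of these compounds alone.

In a functional assay on MGC-803 cells (Homo sapiens) for antiproliferative activity, read by CellTiter-Glo, with a stated time of 72 h (a lower number here means a stronger inhibitor, a higher number a weaker inhibitor), compound 1 `Cc1ccc(-c2cc(/C=C/c3ccc(C(=O)NO)cc3)ccn2)cc1` gives 1910 nM. Compound 2 `O=C(NO)c1ccc(/C=C/c2ccnc(-c3ccc(C(F)(F)F)cc3)c2)cc1` gives > 10000 nM, which is a limit of the assay and not a number. Compound 3 `Cc1ccc(-c2cc(/C=C/c3ccc(C(=O)NO)cc3)c(F)cn2)cc1` gives > 10000 nM, which is also a limit and not a number, so its standing in this assay is known only as a limit.

Compound 4 `O=C(NO)c1ccc(/C=C/c2cc(-c3ccc(C(F)(F)F)cc3)ncc2F)cc1` carries trifluoromethyl in place of methyl on an aromatic carbon, para to a large group, when set against compound 3 (trifluoromethyl in place of methyl on an aromatic carbon). For the measured compounds named here, two measured steps bear on this change. The same exchange appears directly in an at least 5.2-fold higher number from compound 1 to compound 2 (0.71 log units; beyond the scatter). The second step, fluoro in place of hydrogen on an aromatic carbon, is an at least 5.2-fold higher number from compound 1 to compound 3 (0.71 log units; beyond the scatter). Both steps end at the limit of > 10000 nM in this assay, at which 2 of the 3 values shown sit, so their true sizes could be larger than those shown.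

Both changes raised the number, and compound 4 carries both of them. A return towards the value of compound 1 therefore seems unlikely, and a further rise in this assay is expected, though it may not be measurable. The expected size of the change is a step that the limit leaves unreadable from compound 3 to compound 4. For compound 4 the estimated value is 18000 nM, with an expected range from 9000 nM to 50000 nM.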

Compound 4, half-maximal inhibitory concentration: > 10000 nM
Compound 4 ended at the assay's limit; the forecaster's own chance of this, stated with the estimate: 90%; the middle value is on the limit's open side.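

In this assay compound 4 gives > 10000 nM as a limit of the assay and not a number. Compound 2 and compound 3 also stand at limits, so neither step to compound 4 can be read. The compounds shown leave open how far compound 2, compound 3 and compound 4 actually lie from one another.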